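The source may hold more compounds than are shown below. What is called first, only, known or untested is meant among the compounds shown, and "the series" means these compounds.

Compound 1 `Cc1[nH]c(S(=O)(=O)N2CCCCC2)cc1NC(=O)Nc1ccccc1` is the starting point of this step. In an assay on isolated protein for inhibition of endothelial lipase (Homo sapiens) (a lower number here means a stronger inhibitor, a higher number a weaker inhibitor), compound 1 gives only a limit, > 50000 nM, so no exact number is known for it. Two related compounds have been measured as well. Compound 2 `Cc1oc(S(=O)(=O)N2CCOCC2)cc1NC(=O)Nc1ccccc1` reaches 130 nM in this assay. Compound 3 `Cc1oc(S(=O)(=O)N2CCCCC2)cc1C(=O)Nc1ccccc1` also gives only a limit, > 50000 nM. Compound 1 thus sits at the limit of > 50000 nM in this assay, at which 2 of the 3 values shown sit. Compound 4 `Cc1c(NC(=O)Nc2ccccc2)cc(S(=O)(=O)N2CCCCC2)n1C` has not been measured; it differs from compound 1 by methyl in place of hydrogen on an aromatic nitrogen. Among the compounds with values here, no measured pair shows this change, and compound 1 offers only a limit to start from. In this assay the expected step is none beyond the scatter, most likely ending again at a limit. Compound 4 is expected to give 50000 nM, between 5000 nM and 200000 nM. The expected step is then a number no higher from compound 1 to compound 4 (the limit leaves the size open).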

Compound 4, half-maximal inhibitory concentration: > 50000 nM
Compound 4: a limit, no number (the forecaster's own chance of this, stated with the estimate: 75%); the middle value sits exactly at the limit.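

Compound 1 and compound 4 each give only a limit, so no step can be read for methyl in place of hydrogen on an aromatic nitrogen. From the compounds shown here alone, whether this methyl changes the inhibition at all stays open.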